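Azido for hydrogen on the acetyl group of compound 1

The compounds below may be only part of what the source reports. "The series", "measured", "known", "first", "only" and "open" are said of these compounds alone.

Compound 1 `COc1ccc(CN(C(C)=O)c2cc(OC)c(OC)c(OC)c2)cc1O` and compound 2 `C/C=C/C(=O)N(Cc1cccc(O)c1)c1cc(OC)c(OC)c(OC)c1` share a core and were measured in a functional assay on KYSE-450 cells (Homo sapiens) for inhibition, read by MTT assay, with a stated time of 48 h; a higher number here means a weaker inhibitor, a lower number a stronger inhibitor. Among the measured compounds shown here, compound 1 gives 160 nM in this assay, the lowest of the two numbers known. Compound 2 gives 14700 nM, a much higher number, beyond the scatter; the two compounds differ in more than one place, so the two values are compared only as they stand.

Compound 3 `COc1ccc(CN(C(=O)CN=[N+]=[N-])c2cc(OC)c(OC)c(OC)c2)cc1O` is not yet measured. It differs from compound 1 by azido in place of hydrogen on a saturated chain carbon bound to a carbonyl carbon. For the measured compounds named here, no single-point step has yet been measured, so there is no comparison to rest on. The change is small in count and sits on a saturated chain carbon bound to a carbonyl carbon; the expected step of a 2.5-fold higher number from compound 1 to compound 3 (0.40 log units; beyond the scatter) from compound 1 to compound 3 is a modest weakening, possibly none beyond the scatter. Compound 3 is estimated at 400 nM, within 100 nM to 2000 nM.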

Compound 3, half-maximal inhibitory concentration: 160 nM
Estimate against measurement, compound 3: 2.5-fold (0.40 log units) above, and the stated range covers the measured number.
By their numbers in this assay, from the lowest: compounds 1 and 3 (each within the scatter of the next); then compound 2.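

Among the compounds shown here, this is the first single-point step. In this assay, azido in place of hydrogen on a saturated chain carbon bound to a carbonyl carbon reads no change at the digits printed from compound 1 to compound 3 (within the scatter), so this carbon of the acetyl group takes a group of 3 heavy atoms with no shift in the number read. No available measurement bears on the reason for this result.

On these data alone, whether this reading belongs to azido alone or holds for this position more widely stays open, and an amine, a carboxylic acid or a longer chain at the same carbon would separate the two. A single step also leaves open whether azido gives the same outcome on other members of the series, including those with a different acyl group on the shared core.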